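The compounds below may be only part of what the source reports. "The series", "measured", "known", "first", "only" and "open" are said of these compounds alone.

Measured compounds:
compound 1 `Cc1cc(-c2cccc([N+](=O)[O-])c2)c2ncc(CSCCc3ccccc3)n2c1` — 100 ug/mL
compound 2 `COc1cccc(-c2cc(C)c3ncc(CSCCc4ccccc4)n3c2)c1` — 20 ug/mL
compound 3 `COc1cccc(-c2cc(C)cn3c(CSCCc4ccccc4)cnc23)c1` — 100 ug/mL

In an ADME assay on HEL cells (Homo sapiens) for cytotoxicity, with a stated time of 3 days (on this read-out higher numbers stand for lower toxicity in this test and lower numbers for higher toxicity in this test), compound 2 gives the lowest of the three numbers. Compound 1 gives 100 ug/mL in this assay, a higher number than compound 2, beyond the scatter, and compound 3 gives 100 ug/mL, likewise higher and beyond the scatter. Going by the values given here, the one step between compounds that differ in a single place, methoxy in place of nitro on an aromatic carbon, reads no change at the digits printed from compound 1 to compound 3 (within the scatter).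

Compound 4 `Cc1cc(-c2ccccc2O)cn2c(CSCCc3ccccc3)cnc12` is not yet measured. It differs from compound 2 as 2-hydroxyphenyl in place of 3-methoxyphenyl on an aromatic carbon. Among the compounds with values here, no measured step covers this change; the one recorded step concerns a different substituent and was flat. Compound 4 shares its core arrangement with compound 3, whose value is well above that of compound 2, so a step upward from compound 2 to compound 4 is thought plausible but uncertain. Compound 4 is therefore expected to show a 2.5-fold higher number from compound 2 to compound 4 (0.40 log units; beyond the scatter), giving an estimated 50 ug/mL with a range from 20 ug/mL to 100 ug/mL.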

Compound 4, minimum cytotoxic concentration: 100 ug/mL
Beside the measured number, compound 4's estimate is 2.0-fold (0.30 log units) below it, within the range that was stated.
By their numbers in this assay, from the lowest: compound 2; then compounds 1, 3 and 4 (each within the scatter of the next).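

In this assay, putting 2-hydroxyphenyl in place of 3-methoxyphenyl on this aromatic carbon, two atoms from the ring nitrogen, gives a 5.0-fold higher number from compound 2 to compound 4 (0.70 log units; beyond the scatter). This is the first step shown that moves the read-out beyond the scatter, since the only earlier step, methoxy in place of nitro, read no change at the digits printed from compound 1 to compound 3 (within the scatter). Nothing given here accounts for the rise in the number.

The change swaps the oxygen substituent and moves it on the phenyl ring in a single step, so the compounds shown cannot tell which of these goes with the higher number. Going by these compounds, how an amine or a carboxylic acid on that phenyl ring would read in this assay also stays open.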